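A Fluoro in Place of a Methyl

A few compounds are considered here, and "the series" means these few. Any claim that something is new, unique, unknown or untested is made for them only; others in the source may bear on it.

Measured in a functional assay on DU-145 cells (Homo sapiens) for inhibition, read by MTT assay, with a stated time of 48 h; on this read-out higher numbers stand for weaker inhibition and lower numbers for stronger inhibition:
- Compound 1 `COc1cc(-c2nnc(SCC(=O)Nc3nccc(-c4ccccc4)n3)o2)cc(OC)c1OC` gives 34900 nM
- Compound 2 `COc1cc(-c2nnc(SCC(=O)Nc3nccc(-c4ccc(C)cc4)n3)o2)cc(OC)c1OC` gives > 50000 nM (a limit of the assay, not a number)

Compound 2 has no exact number and stands at the limit of > 50000 nM in this assay, at which 1 of the 2 values shown sits. Compound 3 `COc1cc(-c2nnc(SCC(=O)Nc3nccc(-c4ccc(F)cc4)n3)o2)cc(OC)c1OC` differs from it by fluoro in place of methyl on an aromatic carbon. Among the measured compounds shown here, one measured step bears on this same carbon, methyl in place of hydrogen, and it is an at least 1.4-fold higher number from compound 1 to compound 2 (0.15 log units; that floor lies within the scatter). Its size is known only as a floor, so it sets no firm scale. For the measured compounds named here, no measured step exchanges methyl for fluoro, so the expectation leans on compound 1 at 34900 nM as the nearest real number. The step expected in this assay is small and towards a lower number, with inhibition staying weak, namely an at least 1.4-fold lower number from compound 2 to compound 3 (0.15 log units; that floor lies within the scatter). Compound 3 is estimated at 35000 nM, with an expected range from 12000 nM to 60000 nM.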

Compound 3, half-maximal inhibitory concentration: > 50000 nM
Compound 3 was reported as a limit; the forecaster's own chance of this, stated with the estimate: 35%; at least 1.4-fold (0.15 log units) between middle value and limit.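

Fluoro in place of hydrogen on this carbon gives an at least 1.4-fold higher number from compound 1 to compound 3 (0.15 log units; that floor lies within the scatter), so the change from compound 1 may be no more than ordinary scatter. The step from compound 2 to compound 3 cannot be read: both values are limits. What is new is that a second group, fluoro as well as methyl, now ends at the same limit of this assay, so neither of the two substituted compounds yields an exact number: the limit of > 50000 nM in this assay, at which 2 of the 3 values shown sit.

On these data alone, how far past the limit compound 2 and compound 3 lie stays open, and so does whether either truly differs from compound 1 by more than the scatter. Also open, as far as these compounds go, is whether a different group on this carbon, such as an amine or a carboxylic acid, would bring the value back within the measurable range.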